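A few compounds are considered here, and "the series" means these few. Any claim that something is new, unique, unknown or untested is made for them only; others in the source may bear on it.

Of the compounds shown here, three that share one core have been measured in an assay on CHO cells for displacement of a labelled ligand from adenosine receptor A1 (Homo sapiens), read by scintillation counting, with a stated time of 60 min, tested at 10 uM; on this read-out lower numbers stand for less inhibition and higher numbers for more inhibition at the one concentration tested (going by the name of the read-out). Compound 1 `CNC(=O)[C@@]12C[C@@H]1[C@@H](n1cnc3c(NC)nc(C#Cc4ccccc4)nc31)[C@H](O)[C@@H]2O` gives 18% in this assay. Compound 2 `CNC(=O)[C@@]12C[C@@H]1[C@@H](n1cnc3c(NC)nc(C#Cc4ccc(F)cc4)nc31)[C@H](O)[C@@H]2O` carries fluoro in place of hydrogen on an aromatic carbon, and in this assay compound 2 gives 27%. Compound 3 `CNC(=O)[C@@]12C[C@@H]1[C@@H](n1cnc3c(NC)nc(C#Cc4cnn(C)c4)nc31)[C@H](O)[C@@H]2O` carries 1-methyl-1H-pyrazol-4-yl in place of phenyl on a triple-bonded carbon, and in this assay compound 3 gives 35%. Compound 1 thus stands lowest of the three: the step of a number 9 percentage points higher from compound 1 to compound 2 (within the scatter) stays within the scatter, whereas the step of a number 17 percentage points higher from compound 1 to compound 3 (beyond the scatter) lies beyond it.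

Compound 4 `CNC(=O)[C@@]12C[C@@H]1[C@@H](n1cnc3c(NC)nc(C#Cc4ccsc4)nc31)[C@H](O)[C@@H]2O` differs from compound 1 in one place: thiophen-3-yl in place of phenyl on a triple-bonded carbon. Among the compounds with values here, two measured steps bear on this change. The step of a number 9 percentage points higher from compound 1 to compound 2 (within the scatter) shows that a small alteration of the phenyl hardly moves the read-out, and the step of a number 17 percentage points higher from compound 1 to compound 3 (beyond the scatter) shows that exchanging the phenyl for 1-methyl-1H-pyrazol-4-yl raised it modestly. Thiophen-3-yl is, like that group, a five-membered aromatic ring, so a small rise, possibly no larger than the scatter, is expected, and the step of a number 8 percentage points higher from compound 1 to compound 4 (within the scatter) is estimated on that basis. Compound 4 is therefore expected to give 26% in this assay, with a range from 12% to 42%.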

Compound 4, a percentage reported as inhibition, at one concentration (the size of the read-out at that concentration, not a potency): 11%
Compound 4: middle estimate off by 15 percentage points, on the high side; the measured number lies below the stated range.
By their numbers in this assay, from the lowest: compounds 4, 1, 2 and 3 (each within the scatter of the next, the first and the last beyond it).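

Swapping phenyl for thiophen-3-yl on the triple-bonded carbon leaves the read-out in this assay unresolved, with a number a number 7 percentage points lower from compound 1 to compound 4 (within the scatter) and a difference that stays inside the usual scatter, so this ring exchange cannot be told apart from no change at all. The new result also shows that having a five-membered aromatic ring at this position does not by itself bring the higher number seen with 1-methyl-1H-pyrazol-4-yl, as the read-out is a number 24 percentage points lower from compound 3 to compound 4 (beyond the scatter) and is likewise a number 16 percentage points lower from compound 2 to compound 4 (beyond the scatter), both steps lying beyond the scatter, so the identity of the ring matters here and not only its size. Nothing among the data shown accounts for these differences between the rings.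

Going by these compounds, it remains open whether the N-methyl group or the two ring nitrogens of the pyrazole go with the higher number, which a pyrazol-4-yl without the methyl or a pyridin-3-yl ring could help to separate. On these data alone, how thiophen-2-yl, or a phenyl carrying an amine or a carboxylic acid, would read at this position also remains unknown.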